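Methylating One Hydroxy of Compound 3: Expected Outcome

A few compounds are considered here, and "the series" means these few. Any claim that something is new, unique, unknown or untested is made for them only; others in the source may bear on it.

Three hydrazones built on a shared core were measured in an ADME assay on NIH3T3 cells (Mus musculus) for cytotoxicity, read by MTT assay, with a stated time of 24 h; a higher number here means a weaker inhibitor, a lower number a stronger inhibitor. Compound 1 `O=C(CSc1nnc(-c2ccncc2)o1)N/N=C/c1ccc(Cl)cc1` gives 181000 nM in this assay. Compound 2 `O=C(CSc1nnc(-c2ccncc2)o1)N/N=C/c1ccc([N+](=O)[O-])cc1` gives 195000 nM. Compound 3 `O=C(CSc1nnc(-c2ccncc2)o1)N/N=C/c1ccc(O)c(O)c1` gives 154000 nM. The steps among them are all small: a 1.1-fold higher number from compound 1 to compound 2 (0.03 log units; within the scatter); a 1.2-fold lower number from compound 1 to compound 3 (0.07 log units; within the scatter); a 1.3-fold lower number from compound 2 to compound 3 (0.10 log units; within the scatter). Compound 3 therefore stands together with compounds 1 and 2, none of the three separated from another beyond the scatter.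

Compound 4 `COc1cc(/C=N/NC(=O)CSc2nnc(-c3ccncc3)o2)ccc1O` has not yet been measured. It differs from compound 3 by methyl in place of hydrogen on an oxygen on an aromatic ring. Going by the values given here, no measured step touches this oxygen; the exchanges of the whole aryl group, a 1.2-fold lower number from compound 1 to compound 3 (0.07 log units; within the scatter) and a 1.3-fold lower number from compound 2 to compound 3 (0.10 log units; within the scatter), stayed within the scatter, and a single methyl added on one oxygen is expected to move the number no further. The step is estimated as a 1.1-fold higher number from compound 3 to compound 4 (0.03 log units; within the scatter). Compound 4 is expected to give 165000 nM in this assay, with a range from 90000 nM to 300000 nM.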

Compound 4, half-maximal inhibitory concentration: 148000 nM
Beside the measured number, compound 4's estimate is 1.1-fold (0.05 log units) above it; measured number inside the range.
By their numbers in this assay, from the lowest: compounds 4, 3, 1 and 2 (each within the scatter of the next).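

Going by these compounds alone, the methyl on this oxygen is the first change made on the oxygen itself rather than by exchanging the whole aryl group, and in this assay it gives a 1.0-fold lower number from compound 3 to compound 4 (0.02 log units; within the scatter) and so does not separate the methoxy compound from its hydroxy parent. The 4-hydroxy-3-methoxyphenyl group also stays together with the two other aryl groups, with a 1.3-fold lower number from compound 2 to compound 4 (0.12 log units; within the scatter) and a 1.2-fold lower number from compound 1 to compound 4 (0.09 log units; within the scatter) as its steps, and none of the four compounds stands apart from another in this read-out. Nothing available bears on why the methyl leaves compound 3 and compound 4 together.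

On these data alone, whether a longer chain such as propyl, or a chain ending in an amine or a carboxylic acid, on this same oxygen would also stay within the scatter remains open. The compounds shown also do not tell whether methyl on the remaining hydroxy of the 4-hydroxy-3-methoxyphenyl group would read the same.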